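From Compound 1 to Compound 4: Swapping the Aryl Ring

A few compounds are considered here, and "the series" means these few. Any claim that something is new, unique, unknown or untested is made for them only; others in the source may bear on it.

Measured so far in a functional assay on DU-145 cells (Homo sapiens) for inhibition, read by trypan blue exclusion, with a stated time of 96 h; a higher number here means a weaker inhibitor of growth, a lower number a stronger inhibitor of growth:
compound 1, `Cc1ccc(CS(=O)(=O)/C(=C/c2ccc(Br)cc2)C(=O)c2ccc(Cl)cc2)cc1`, gives 25000 nM
compound 3, `Cc1ccsc1/C=C(/SCc1ccc(F)cc1)C(=O)c1ccc(Cl)cc1`, gives 50000 nM
compound 2, `O=C(/C(=C\c1ccc(Br)cc1)S(=O)(=O)Cc1ccc(F)cc1)c1ccc(Cl)cc1`, gives > 100000 nM, which is a limit of the assay and not a number.

Compound 1 sits at the lowest of the two numbers in this assay, with compound 3 nearest; the gap between these two lies within the usual scatter, so no order between them can be claimed. Compound 2 differs from compound 1 in one place, and that step, an at least 4.0-fold higher number from compound 1 to compound 2 (0.60 log units; beyond the scatter), lands on the limit (the limit of > 100000 nM in this assay, at which 1 of the 3 values shown sits).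

Compound 4, `Cc1ccc(CS(=O)(=O)/C(=C/c2ccc(C)s2)C(=O)c2ccc(Cl)cc2)cc1`, has not yet been measured. It differs from compound 1 by 5-methylthiophen-2-yl in place of 4-bromophenyl on a double-bonded chain carbon bound to a double-bonded chain carbon. Among the measured compounds shown here, no measured step concerns this change: the one measured step alters a group on the benzylic ring, not the ring on the double-bonded chain carbon, and compound 3, which also carries a thiophene ring there, differs from compound 1 in more than one place. With no guide from the measured steps, the expectation is a change no larger than the scatter in this assay, in either direction. Compound 4 is therefore estimated at 35000 nM, with a range of 12000 nM to 100000 nM, meaning an expected step of a 1.4-fold higher number from compound 1 to compound 4 (0.15 log units; within the scatter).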

Compound 4, concentration for 50% growth inhibition: 25000 nM
Estimate against measurement, compound 4: 1.4-fold (0.15 log units) above; the range from low to high includes it.
By their numbers in this assay, from the lowest: compounds 1, 4 and 3 (each within the scatter of the next). At a limit, above all of these: compound 2.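

In this assay, the step from 4-bromophenyl to 5-methylthiophen-2-yl on a double-bonded chain carbon bound to a double-bonded chain carbon gives no change at the digits printed from compound 1 to compound 4 (within the scatter). Among the compounds shown here, the only earlier single-place step concerned a different site, so this is the first direct reading at this position: here, a five-membered aromatic ring with a sulfur atom can replace a six-membered carbon ring with no measurable difference in growth inhibition. Nothing measured here explains why the two rings read alike.

Going by these compounds, only these two rings have been compared at this position, so it remains open whether an aromatic ring carrying an amine or a carboxylic acid, or a longer carbon chain, would read the same. On these data alone, it is also open whether fluoro in place of methyl on an aromatic carbon would weaken compound 4 as it weakened compound 1.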